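A few compounds are considered here, and "the series" means these few. Any claim that something is new, unique, unknown or untested is made for them only; others in the source may bear on it.

Of the compounds shown here, three have been measured in a functional assay on MDA-MB-231 cells (Homo sapiens) for inhibition, read by MTT assay, with stated times of 18 h and 4 h; a lower number here means a stronger inhibitor, a higher number a weaker inhibitor. Compound 1 `CCCCCCCCCCOP(=O)(O)OCCSC(=S)N1CCN(C)CC1` gives 29000 nM, compound 2 `CCCCCCCCCCOP(=O)(O)OCCSC(=S)N1CCCCC1` gives 24600 nM, and compound 3 `CCCCCCOP(=O)(O)OCCSC(=S)N1CCCCC1` gives 85000 nM, the highest of the three numbers. Compound 4 `CCCCCCOP(=O)(O)OCCSC(=S)N1CCN(C)CC1` has not yet been measured.

Compound 3 and compound 4 share a core that differs from the core of compound 1 and compound 2 in one place: hydrogen in place of butyl on a saturated chain carbon, six bonds along the chain from an oxygen on an unsaturated carbon. That shortening of the chain gave a 3.5-fold higher number from compound 2 to compound 3 (0.54 log units; beyond the scatter).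

The change from compound 3 to compound 4 is 4-methylpiperazin-1-yl in place of piperidin-1-yl on a thiocarbonyl carbon. The same change has been measured once already, from compound 2 to compound 1: 4-methylpiperazin-1-yl in place of piperidin-1-yl on a thiocarbonyl carbon. There it gave a 1.2-fold higher number from compound 2 to compound 1 (0.07 log units; within the scatter). The surroundings of the change are described in the same words for both pairs, so this is the same change made on a second core.

Within the data shown here, with only one earlier example, the expectation rests on a 1.2-fold higher number from compound 2 to compound 1 (0.07 log units; within the scatter) and is that the step will be of similar size, a 1.1-fold higher number from compound 3 to compound 4 (0.05 log units; within the scatter), in this assay. Compound 4 is therefore expected to give about 95000 nM in this assay. The estimate for compound 4 is likely to fall between 45000 nM and 200000 nM.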

Compound 4, half-maximal inhibitory concentration: 73000 nM
Beside the measured number, compound 4's estimate is 1.3-fold (0.11 log units) above it; the range from low to high includes it.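

In this assay, putting 4-methylpiperazin-1-yl in place of piperidin-1-yl on the thiocarbonyl carbon gave a 1.2-fold lower number from compound 3 to compound 4 (0.07 log units; within the scatter), so the swap made no clear difference on either core, and the two results agree: the same change on two cores in this assay, a 1.2-fold higher number (0.07 log units; within the scatter) from compound 2 to compound 1 and a 1.2-fold lower number (0.07 log units; within the scatter) from compound 3 to compound 4, 1.4-fold (0.14 log units) apart, within the scatter of two such steps

The shortening of the chain also carried over, giving a 2.5-fold higher number from compound 1 to compound 4 (0.40 log units; beyond the scatter) with the 4-methylpiperazin-1-yl group in place, and it raised the number clearly on both cores: the same change on two cores in this assay, a 3.5-fold higher number (0.54 log units; beyond the scatter) from compound 2 to compound 3 and a 2.5-fold higher number (0.40 log units; beyond the scatter) from compound 1 to compound 4, 1.4-fold (0.14 log units) apart, within the scatter of two such steps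

This shows that, for these four compounds, the two changes act independently of each other, but two cores are a small sample, so it does not show that the ring swap would leave the number unchanged on every core in the series.

On these data alone, it remains open whether a longer chain would lower the number further, since only these two chain lengths appear here. As far as these compounds go, it also remains open whether a morpholin-4-yl ring or an open-chain amine on the thiocarbonyl carbon would match the two rings seen so far.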